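This account rests on a few compounds, and the source may have more. Where it says the series, first, only, none or still open, it means among the compounds named here.

Measured so far, in an assay on isolated protein for inhibition of Indoleamine 2,3-dioxygenase 1 (Homo sapiens), read by spectrophotometry; on this read-out lower numbers stand for stronger inhibition and higher numbers for weaker inhibition:
- compound 1, `O/N=C(/Nc1cccc(F)c1)c1ccc2occc2c1`, gives 32700 nM
- compound 2, `CC1CCN(C(=O)c2cccc(N/C(=N/O)c3ccc4occc4c3)c2)CC1`, gives only a limit of the assay, > 30000 nM
- compound 3, `OCc1cc2cc(/C(=N\O)Nc3cccc(F)c3)ccc2o1`, gives 1700 nM

Compound 3 holds the lowest of the two readable numbers in this assay; the nearest is compound 1, and the step of a 19-fold lower number from compound 1 to compound 3 (1.28 log units; beyond the scatter) separates them. The limit of > 30000 nM in this assay, at which 1 of the 3 values shown sits, leaves the step that the limit leaves unreadable from compound 1 to compound 2 unreadable.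

Compound 4, `OCc1cc2cc(/C(=N\O)Nc3cccc(Br)c3)ccc2o1`, has not yet been measured in this assay. It differs from compound 3 in one place: bromo in place of fluoro on an aromatic carbon. Neither of the two measured steps touches this change; one swapped a hydroxymethyl for a hydrogen on the shared core, the other replaced the fluoro with a large carbonyl-bearing group and ran into the limit. Going by the values given here, there is thus no measured step that bears directly on exchanging one halogen for another. The step of a 1.1-fold lower number from compound 3 to compound 4 (0.05 log units; within the scatter) is therefore expected to stay within the scatter. Compound 4 is expected to give about 1500 nM, between 500 nM and 5000 nM.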

Compound 4, half-maximal inhibitory concentration: 710 nM
Compound 4: the middle estimate sits 2.1-fold (0.32 log units) above what was measured; measured number inside the range.
By their numbers in this assay, from the lowest: compound 4; then compound 3; then compound 1.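

In this assay, going from 3-fluorophenyl to 3-bromophenyl gives a 2.4-fold lower number from compound 3 to compound 4 (0.38 log units; beyond the scatter). Going by these compounds alone, the step is modest but real, so the choice of halogen at this place on the ring affects the read-out, which the earlier compounds could not show: the only earlier change at this place, from fluoro to the much larger (4-methylpiperidin-1-yl)carbonyl group in compound 2, ended at a limit of the assay and gave no readable step. Nothing measured here accounts for the difference between the two halogens.

From the compounds shown here alone, it remains open whether a chloro, methyl, methoxy or amino group at this place would fit the same trend or break from it. Also open, going by these compounds, is whether bromo would give a similar step on a core without the hydroxymethyl group.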